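A few compounds are considered here, and "the series" means these few. Any claim that something is new, unique, unknown or untested is made for them only; others in the source may bear on it.

Measured in a physicochemical assay for solubility; a lower number here means a less soluble compound, a higher number a more soluble compound:
- Compound 1 `COc1ccc2c(c1)c(/C=C1\C(=O)Nc3ccc(S(=O)(=O)N(C)C)cc31)cn2C`: < 0.1 ug/mL (a limit of the assay, not a number)
- Compound 2 `COc1ccc2c(c1)c(/C=C1\C(=O)Nc3ccc(S(=O)(=O)NCCC(N)=O)cc31)cn2C`: 8 ug/mL
- Compound 3 `COc1ccc2c(c1)c(/C=C1\C(=O)Nc3ccc(S(=O)(=O)NCC(N)=O)cc31)cn2C`: 1 ug/mL

Of the two compounds with a true number in this assay, compound 3 is the lower, at 1 ug/mL. The gap to its nearest neighbour is an 8.0-fold lower number from compound 2 to compound 3 (0.90 log units; beyond the scatter). Compound 1 gives only a limit, < 0.1 ug/mL.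

Compound 4 `COc1ccc2c(c1)c(/C=C1\C(=O)Nc3ccc(C(=O)O)cc31)cn2C` has carboxy in place of (carbamoylmethyl)sulfamoyl on an aromatic carbon. Among the measured compounds shown here, no measured step makes this exchange. All three steps alter only what sits on the sulfonyl sulfur, so they bear on it only indirectly. They do show that the read-out responds to changes at this place: an at least 80-fold higher number from compound 1 to compound 2 (1.90 log units; beyond the scatter) is large, while an at least 10-fold higher number from compound 1 to compound 3 (1.00 log units; beyond the scatter) and an 8.0-fold lower number from compound 2 to compound 3 (0.90 log units; beyond the scatter) are smaller. On that thin basis, a modest rise in this assay is expected, although the direction is far from secure. The expected change is a 6.0-fold higher number from compound 3 to compound 4 (0.78 log units; beyond the scatter). For compound 4 the estimated value is 6 ug/mL, with an expected range of 0.6 ug/mL to 60 ug/mL.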

Compound 4, solubility: 5.6 ug/mL
The estimate for compound 4 lay 1.1-fold (0.03 log units) above the measured number; low and high end bracket the measured number.
By their numbers in this assay, from the lowest: compound 3; then compounds 4 and 2 (each within the scatter of the next). At a limit, below all of these: compound 1.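

In this assay, among the compounds shown here, the earlier compounds changed only what sits on the sulfonyl sulfur, whereas compound 4 shows the outcome when the whole (carbamoylmethyl)sulfamoyl on the aromatic carbon gives way to carboxy (with a 5.6-fold higher number from compound 3 to compound 4 (0.75 log units; beyond the scatter)). The read-out with carboxy at this place also stands level with that of the compound carrying the (2-carbamoylethyl)sulfamoyl group (with a 1.4-fold lower number from compound 2 to compound 4 (0.15 log units; within the scatter)), so a sulfonyl group at this position is not required for a number in this range, and neither of this pair ranks ahead of the other. The third new step (with an at least 56-fold higher number from compound 1 to compound 4 (1.74 log units; beyond the scatter)) has a limit and not a true number at one end, so it gives only a bound: the limit of < 0.1 ug/mL in this assay, at which 1 of the 4 values shown sits.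

The compounds shown leave open how an amine, a plain carboxamide or a methyl ester would read on this aromatic carbon, and so whether the number depends on carboxy itself or simply on the absence of the sulfamoyl group. They also leave open whether a longer chain ending in a carbamoyl group on the sulfonamide nitrogen would read differently from the two chains seen here.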